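This account rests on a few compounds, and the source may have more. Where it says the series, first, only, none or still open, it means among the compounds named here.

Three compounds share one core and differ only in a single group on an aromatic carbon. Compound 1 `COc1nc2ccc(Br)cc2cc1C(c1ccccc1)n1cc(-c2ccc(Br)cc2)nn1` carries a 4-bromophenyl there, compound 2 `CCCCCCCc1cn(C(c2ccccc2)c2cc3cc(Br)ccc3nc2OC)nn1` a heptyl and compound 3 `CCCCCCc1cn(C(c2ccccc2)c2cc3cc(Br)ccc3nc2OC)nn1` a hexyl. In an ADME assay on SK-OV-3 cells (Homo sapiens) for cytotoxicity, read by sulforhodamine B assay, with a stated time of 48 h, tested at 10 uM (on this read-out higher numbers stand for more inhibition at the one concentration tested (going by the name of the read-out) and lower numbers for less inhibition), compound 1 gives 13.4%, compound 2 gives 10.5% and compound 3 gives 7.17%. Compound 3 thus holds the lowest number of the three, yet the step of a number 6.2 percentage points lower from compound 1 to compound 3 (within the scatter) and the step of a number 3.3 percentage points lower from compound 2 to compound 3 (within the scatter) both lie within the scatter, so the three numbers cannot be told apart with confidence.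

Compound 4 `CCCCc1cn(C(c2ccccc2)c2cc3cc(Br)ccc3nc2OC)nn1` is not yet measured. It differs from compound 3 in this way: hydrogen in place of ethyl on a saturated chain carbon, four bonds along the chain from an aromatic carbon. The chain is shortened again, as it was in the step from compound 2 to compound 3, which read a number 3.3 percentage points lower from compound 2 to compound 3 (within the scatter), and the earlier step of a number 2.9 percentage points lower from compound 1 to compound 2 (within the scatter) was also within the scatter. Among the measured compounds shown here, none of the measured steps moved this assay beyond its scatter, so for compound 4 a step of a number 1.2 percentage points lower from compound 3 to compound 4 (within the scatter) is expected, too small to count as a real change. Compound 4 is therefore estimated at 6%, with a likely range from 0% to 15% in this assay.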

Compound 4, a percentage reported as inhibition, at one concentration (the size of the read-out at that concentration, not a potency): 11.1%
For compound 4 the middle estimate is 5.1 percentage points below the measured one; the range from low to high includes it.
By their numbers in this assay, from the lowest: compounds 3, 2, 4 and 1 (each within the scatter of the next).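

Cutting the hexyl chain down to butyl gives a number 3.9 percentage points higher from compound 3 to compound 4 (within the scatter) and cutting the heptyl chain down to butyl gives a number 0.6 percentage points higher from compound 2 to compound 4 (within the scatter) in this assay, so the small downward drift from heptyl to hexyl does not carry on to butyl, and chain length across these three shows no trend that can be told from the scatter. Butyl also cannot be told apart from the aromatic group at this position: replacing 4-bromophenyl with butyl gives a number 2.3 percentage points lower from compound 1 to compound 4 (within the scatter) and thus adds a third chain that reads the same as the ring within the scatter. Nothing on hand explains these numbers or ties them to any property of the groups.

What the compounds shown leave open is whether any group on this aromatic carbon can move the reading beyond the scatter, for instance a chain ending in an amine or a carboxylic acid, or a much longer chain such as dodecyl. From the compounds shown here alone, the shorter end of the series, methyl or ethyl in place of butyl, also remains open, as does the reading at any other concentration.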